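The compounds below may be only part of what the source reports. "The series", "measured", "known", "first", "only" and "open" are said of these compounds alone.

In a functional assay on K562 cells (Homo sapiens) for inhibition, read by trypan blue exclusion, with a stated time of 72 h (on this read-out lower numbers stand for stronger inhibition and higher numbers for weaker inhibition), two compounds sharing one core have been measured so far. Compound 1 `Cn1c(=O)c(S(=O)(=O)c2ccc(C(=O)O)cc2)cc2cnc(Nc3ccc4[nH]ccc4c3)nc21` gives 5000 nM and compound 2 `Cn1c(=O)c(S(=O)(=O)c2ccc(Br)cc2)cc2cnc(Nc3ccc4[nH]ccc4c3)nc21` gives 5000 nM. Compound 2 therefore stands level with compound 1, its nearest and only neighbour on these numbers.

The next compound, compound 3 `Cn1c(=O)c(S(=O)(=O)c2ccc(F)cc2[N+](=O)[O-])cc2cnc(Nc3ccc4[nH]ccc4c3)nc21`, has not yet been measured. It differs from compound 2 on a sulfonyl sulfur, where 4-fluoro-2-nitrophenyl takes the place of 4-bromophenyl: 4-fluoro-2-nitrophenyl in place of 4-bromophenyl on a sulfonyl sulfur.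

Within the data shown here, only one measured step bears on this change. In no change at the digits printed from compound 1 to compound 2 (within the scatter), bromo replaced carboxy on an aromatic carbon of the group carried by that same sulfonyl sulfur, and the reading did not move beyond the scatter. Among the measured compounds shown here, this is thin evidence, since it is a single step and no measured compound carries 4-fluoro-2-nitrophenyl. The data therefore point in no direction, and no shift beyond the scatter is expected in this assay, although the uncertainty is wide. The expected change is no change at the digits printed from compound 2 to compound 3 (within the scatter). For compound 3 the estimated value is 5000 nM, with an expected range of 1500 nM to 12000 nM.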

Compound 3, half-maximal inhibitory concentration: 900 nM
Beside the measured number, compound 3's estimate is 5.6-fold (0.74 log units) above it; measured number outside the range, below it.
By their numbers in this assay, from the lowest: compound 3; then compounds 1 and 2 (each within the scatter of the next).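

In this assay, the group on the sulfonyl sulfur proves able to move the reading, which the earlier pair did not show: bromo in place of carboxy gave no change at the digits printed from compound 1 to compound 2 (within the scatter), whereas 4-fluoro-2-nitrophenyl in place of 4-bromophenyl gives a 5.6-fold lower number from compound 2 to compound 3 (0.74 log units; beyond the scatter). The comparison with the carboxy-bearing compound comes out the same way, with 4-fluoro-2-nitrophenyl in place of 4-carboxyphenyl giving a 5.6-fold lower number from compound 1 to compound 3 (0.74 log units; beyond the scatter), so compound 3 holds the lowest number of the three, with its steps to both others beyond the scatter. Nothing measured here accounts for this drop.

The compounds shown leave open whether the lower number goes with the fluoro, with the nitro or only with the two together, a question that a phenyl ring carrying the fluoro alone or the nitro alone on the same sulfonyl sulfur would settle. They also leave open whether an amine or a methoxy group in place of the nitro would keep the number of compound 3 in this assay's range or return it to the level shared by compound 1 and compound 2.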